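A Methoxy Step Repeated on a Fluorinated Core

This account rests on a few compounds, and the source may have more. Where it says the series, first, only, none or still open, it means among the compounds named here.

Compound 1 `COc1cc([C@H]2CC(C)(O)[C@@H]3CC[C@@H](C)C[C@H]3O2)ccc1O` is the reference point of this small set. In an ADME assay on MDCK cells (Canis lupus familiaris) for cytotoxicity, read by MTT assay, with a stated time of 48 h (on this read-out higher numbers stand for lower toxicity in this test and lower numbers for higher toxicity in this test), compound 1 gives 411000 nM. Compound 2 `COc1cc([C@H]2CC(C)(O)[C@@H]3CC[C@@H](C)C[C@H]3O2)cc(OC)c1O` carries one more group than compound 1, namely (methoxy in place of hydrogen on an aromatic carbon), and in this assay compound 2 gives 473000 nM. That change made a 1.2-fold higher number from compound 1 to compound 2 (0.06 log units; within the scatter).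

Compound 3 `COc1ccc([C@H]2CC(C)(F)[C@@H]3CC[C@@H](C)C[C@H]3O2)cc1` rests on a different core; how its core differs from that of compound 1 is not broken down here. In this assay compound 3 gives 171000 nM, the lowest of the three measured numbers, and its distance from compound 1 as well as from compound 2 lies beyond the usual scatter.

Compound 4 `COc1ccc([C@H]2CC(C)(F)[C@@H]3CC[C@@H](C)C[C@H]3O2)c(OC)c1` has not been measured yet. It differs from compound 3 by methoxy in place of hydrogen on an aromatic carbon. Among the measured compounds shown here, this is the same kind of change as the one from compound 1 to compound 2, but the surroundings are not the same: in compound 2 the new group sits ortho to a hydroxy group, meta to a large group and meta to a methoxy group, whereas in compound 4 it sits ortho to a large group and meta to a methoxy group.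

The expected step for compound 4 is a 1.1-fold higher number from compound 3 to compound 4 (0.05 log units; within the scatter), because a 1.2-fold higher number from compound 1 to compound 2 (0.06 log units; within the scatter) stayed within the scatter. For compound 4 the estimate in this assay is 190000 nM, expected to fall between 90000 nM and 400000 nM.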

Compound 4, half-maximal cytotoxic concentration: 379000 nM
Estimate against measurement, compound 4: 2.0-fold (0.30 log units) below, and the stated range covers the measured number.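

In this assay, methoxy in place of hydrogen on an aromatic carbon gave a 2.2-fold higher number from compound 3 to compound 4 (0.35 log units; beyond the scatter), so here the higher number points to lower toxicity in this test. On the core of compound 1, the same change gave a step that stayed within the scatter, yet the two steps cannot be told apart when set side by side: the same change on two cores in this assay, a 1.2-fold higher number (0.06 log units; within the scatter) from compound 1 to compound 2 and a 2.2-fold higher number (0.35 log units; beyond the scatter) from compound 3 to compound 4, 1.9-fold (0.28 log units) apart, within the scatter of two such steps. Among the compounds shown here, this shows that the change can be carried from one core to the other without a detectable difference in the size of its step, but it does not show that the two steps are equal, and with only one pair on each core, and the new group in different surroundings in each pair, it says nothing about how the change would behave on further cores.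

From the compounds shown here alone, it remains open whether a different group in the same place, such as an amine, a carboxylic acid or a longer chain, would shift the number on either core. The compounds shown also leave open what methoxy would do elsewhere on the aromatic ring of compound 3, and which of the differences between the two cores matters for this read-out.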